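A few compounds are considered here, and "the series" means these few. Any claim that something is new, unique, unknown or untested is made for them only; others in the source may bear on it.

Measured so far:
compound 1, `O=C(CN(c1ncnc2c1ncn2C1CCCCO1)C1CC1)NCC(=O)OCc1ccccc1`, 55.7%
compound 2, `O=C(CN(c1nc(Cl)nc2[nH]cnc12)C1CC1)N[C@@H](CC(=O)OCc1ccccc1)C(=O)OCc1ccccc1`, 34.7%

Both numbers come from a functional assay on the whole organism (Tail, strain ICR) with Mus musculus as the target, in the tail flick test, with a stated time of 30 min, at a dose of 25 umol/kg by the oral route; on this read-out lower numbers stand for a weaker effect and higher numbers for a stronger effect at the one dose given. Compound 1 holds the higher of the two numbers; compound 2 sits lower by a margin that goes beyond the usual scatter of this assay. Compound 3, `O=C(CN(c1ncnc2c1ncn2C1CCCCO1)C1CC1)N[C@@H](CC(=O)OCc1ccccc1)C(=O)OCc1ccccc1`, has not yet been measured in this assay. It keeps the core of compound 1 and differs from it in one place: (benzyloxycarbonyl)methyl in place of hydrogen on a saturated chain carbon bound to an amide-type nitrogen and a carbonyl carbon. Going by the values given here, no pair of measured compounds that differ in a single place is available, so the size of this step cannot be read off from existing data and can only be expected. The expected step of a number 10.7 percentage points lower from compound 1 to compound 3 (beyond the scatter) is a modest decrease, one that may well stay within the scatter of the method. Compound 3 is estimated at 45%, with a range from 25% to 65%.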

Compound 3, a percentage reported as activity, at one dose (the size of the read-out at that dose, not a potency): 31.8%
Compound 3: the middle estimate sits 13.2 percentage points above what was measured, within the range that was stated.
By their numbers in this assay, from the lowest: compounds 3 and 2 (each within the scatter of the next); then compound 1.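

Placing (benzyloxycarbonyl)methyl in place of hydrogen on a saturated chain carbon bound to an amide-type nitrogen and a carbonyl carbon gives a number 23.9 percentage points lower from compound 1 to compound 3 (beyond the scatter) in this assay, so this position is not indifferent to substitution. Going by these compounds alone, this is the first single-place step, and it ties a weaker effect at the one dose given to this change with the core of compound 1 held constant. Nothing available accounts for the step.

The compounds shown leave open whether the step follows from the benzyl ester or from the added chain as a whole; a methyl group, a free carboxylic acid or an amine at the same carbon would help separate these. On these data alone, whether a step of this size also holds on the core of compound 2 stays open as well.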